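Series notes: swapping the aryl group on the imine carbon

This account rests on a few compounds, and the source may have more. Where it says the series, first, only, none or still open, it means among the compounds named here.

Measured so far in a functional assay on RAW264.7 cells (Mus musculus) for cytotoxicity, read by MTT assay, with a stated time of 48 h, tested at 50 uM; a higher number here means a stronger effect of the compound at the concentration tested, a lower number a weaker effect:
compound 1 `CS(=O)(=O)c1ccc(Cc2nnc3n2N=C(c2ccccc2)CS3)cc1` gives 46.7%
compound 2 `CS(=O)(=O)c1ccc(Cc2nnc3n2N=C(c2cc(Cl)sc2S(N)(=O)=O)CS3)cc1` gives 27.5%
compound 3 `CS(=O)(=O)c1ccc(Cc2nnc3n2N=C(c2cc4ccccc4c(=O)o2)CS3)cc1` gives 14.9%

Compound 2 stands second highest of these three numbers; compound 3 lies lower beyond the scatter, compound 1 higher beyond the scatter. Among the measured compounds shown here, one measured step touches the group on the carbon with a double bond to nitrogen: a number 19.2 percentage points lower from compound 1 to compound 2 (beyond the scatter), a modest drop when the thiophene replaced phenyl.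

Compound 4 `CS(=O)(=O)c1ccc(Cc2nnc3n2N=C(c2ccc(O)c(C(N)=O)c2)CS3)cc1` differs from compound 2 in one place: 3-carbamoyl-4-hydroxyphenyl in place of 5-chloro-2-sulfamoylthiophen-3-yl on a carbon with a double bond to nitrogen. The change brings back a six-membered aromatic ring of carbon only at that position, as in compound 1, though now carrying a carbamoyl and a hydroxy group that compound 1 lacks. For the measured compounds named here, no measured pair shows what those two groups do, so the single step from compound 1 to compound 2 is the only guide, and only part of it can be assumed to reverse. The expected step is a number 7.5 percentage points higher from compound 2 to compound 4 (within the scatter), a modest rise. Compound 4 is therefore estimated at 35%, in the range 18% to 52%.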

Compound 4, a percentage reported as activity, at one concentration (the size of the read-out at that concentration, not a potency): 33.1%
The estimate for compound 4 lay 1.9 percentage points above the measured number; the range from low to high includes it.
By their numbers in this assay, from the lowest: compound 3; then compounds 2 and 4 (each within the scatter of the next); then compound 1.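

In this assay, 3-carbamoyl-4-hydroxyphenyl in place of 5-chloro-2-sulfamoylthiophen-3-yl on the carbon with a double bond to nitrogen gives a number 5.6 percentage points higher from compound 2 to compound 4 (within the scatter), so this exchange of a five-membered aromatic ring for a six-membered one is not resolved by this read-out. Against the unsubstituted phenyl, the same group gives a number 13.6 percentage points lower from compound 1 to compound 4 (beyond the scatter), showing that a six-membered aromatic ring of carbon only at this position does not by itself keep the number of compound 1 once the carbamoyl and hydroxy groups are present. No measured evidence bears on the cause of either step.

The compounds shown leave open whether the carbamoyl or the hydroxy group alone goes with the step from phenyl. Also open, going by these compounds, is how this assay would read with a carboxylic acid in place of the carbamoyl group.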